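Chloro to methyl on the phenyl of compound 2

The source may hold more compounds than are shown below. What is called first, only, known or untested is meant among the compounds shown, and "the series" means these compounds.

Measured so far:
compound 1, `O=C(CCC(=O)OCCCCCCSc1ccc([N+](=O)[O-])c2nonc12)Nc1ccccc1`, 2490 nM
compound 2, `O=C(CCC(=O)OCCCCCCSc1ccc([N+](=O)[O-])c2nonc12)Nc1ccccc1Cl`, 2950 nM
compound 3, `Cc1ccccc1NC(=O)CCC(=O)OCCCCCCSc1ccc([N+](=O)[O-])c2nonc12`, not yet measured

In an ADME assay on HUVEC cells (Homo sapiens) for cytotoxicity, read by MTT assay, with a stated time of 72 h (a higher number here means a weaker inhibitor, a lower number a stronger inhibitor), compound 1 gives 2490 nM and compound 2 gives 2950 nM. Within the data shown here, the only step between the two, a 1.2-fold higher number from compound 1 to compound 2 (0.07 log units; within the scatter), lies within the scatter. On the numbers shown compound 2 carries the highest of the two values, with compound 1 nearest, the two values within the scatter of each other.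

Compound 3 differs from compound 2 by methyl in place of chloro on an aromatic carbon. Among the measured compounds shown here, the only measured step that bears on this place is a 1.2-fold higher number from compound 1 to compound 2 (0.07 log units; within the scatter), which showed that a change of one heavy atom there left this assay essentially unchanged. The swap of chloro for methyl is again a change of one heavy atom at the same place, so no step beyond the scatter is expected in this assay , in either direction.

Compound 3 is therefore estimated at 2700 nM, with a range from 1400 nM to 5400 nM, an expected step of a 1.1-fold lower number from compound 2 to compound 3 (0.04 log units; within the scatter).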

Compound 3, half-maximal inhibitory concentration: 1410 nM
For compound 3 the middle estimate is 1.9-fold (0.28 log units) above the measured one; measured number inside the range.
By their numbers in this assay, from the lowest: compounds 3, 1 and 2 (each within the scatter of the next, the first and the last beyond it).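

Among these compounds, the swap of chloro for methyl gives a 2.1-fold lower number from compound 2 to compound 3 (0.32 log units; beyond the scatter) in this assay, the first step beyond the scatter, though a modest one. Neither group separates from the hydrogen of compound 1: methyl in place of hydrogen gives a 1.8-fold lower number from compound 1 to compound 3 (0.25 log units; within the scatter), and chloro in place of hydrogen gives a 1.2-fold higher number from compound 1 to compound 2 (0.07 log units; within the scatter), so at this place, ortho to a large group, only the two substituted compounds stand apart. No data at hand explain this gap between methyl and chloro.

As far as these compounds go, whether the gap is specific to this pair of groups remains open, and a methoxy group, an amine or a carboxylic acid at the same place would test that. Three compounds also cannot show whether the gap would persist on a different core.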